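The source may report more compounds than this note shows. Statements on the series, on what has been measured and on what is new or still open speak of the compounds shown alone.

Compound 2 `NC(=O)c1nn(C2O[C@H](CO)[C@@H](O)[C@H]2O)cc1[N+](=O)[O-]` stands at a limit in a functional assay on Vero cells (Chlorocebus sabaeus); a lower number here means a stronger inhibitor, a higher number a weaker inhibitor: in this assay compound 2 gives > 1730 uM, a limit rather than a number. Compound 1 `NC(=O)c1ccn(C2O[C@H](CO)[C@@H](O)[C@H]2O)n1` likewise returns only a limit, > 1030 uM. Compound 3 `NC(=O)c1nn(C2O[C@H](CO)[C@@H](O)[C@H]2O)cc1Br` also returns a limit, > 1550 uM. Compound 4 `Cc1c([N+](=O)[O-])c(C(N)=O)nn1C1O[C@H](CO)[C@@H](O)[C@H]1O` differs from compound 2 by methyl in place of hydrogen on an aromatic carbon. The measured steps on this core are a step that the two limits leave unreadable from compound 1 to compound 2, a step that the two limits leave unreadable from compound 1 to compound 3 and a step that the two limits leave unreadable from compound 2 to compound 3; none has a readable size, as each value rests at a limit: the limit of > 1030 uM in this assay, at which 1 of the 3 values shown sits, (the limit of > 1550 uM in this assay, at which 1 of the 3 values shown sits), (the limit of > 1730 uM in this assay, at which 1 of the 3 values shown sits). Among the compounds with values here, no measured step therefore supplies a direction; the expected step of an at least 1.0-fold lower number from compound 2 to compound 4 (0.00 log units; that floor lies within the scatter) is none beyond the scatter, with a limit again the likely outcome. Compound 4 is thus estimated at 1700 uM, expected between 400 uM and 6000 uM.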

Compound 4, concentration for 50% inhibition: > 1650 uM
Compound 4 was reported as a limit; the forecaster's own chance of this, stated with the estimate: 85%; the middle value lies beyond the limit too.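

Compound 2 and compound 4 both stand only at limits in this assay, so the step for methyl in place of hydrogen on an aromatic carbon cannot be read. The compounds shown leave open whether any of them has a measurable inhibitory concentration.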